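Pyrrolylmethyl in Place of Dimethylpyrazolyl: Compound 3 Expected

The source may hold more compounds than are shown below. What is called first, only, known or untested is meant among the compounds shown, and "the series" means these compounds.

Compound 1 `NC(=O)C1(c2cccc(Sc3ccc(-n4cnnc4)cc3)c2)CCOCC1`: > 1000 nM
Compound 2 `Cc1cc(C)n(-c2ccc(Sc3cccc(C4(C(N)=O)CCOCC4)c3)cc2)n1`: > 1000 nM

In a functional assay on blood for inhibition of Polyunsaturated fatty acid 5-lipoxygenase (Homo sapiens) (a higher number here means a weaker inhibitor, a lower number a stronger inhibitor), compound 1 reaches only a limit, > 1000 nM. Compound 2 likewise gives only the limit > 1000 nM in this assay. The step that the two limits leave unreadable from compound 1 to compound 2 is therefore unreadable, as the limit of > 1000 nM in this assay, at which 2 of the 2 values shown sit, records. Compound 3 `NC(=O)C1(c2cccc(Sc3ccc(Cn4cccc4)cc3)c2)CCOCC1` differs from compound 2 by (1H-pyrrol-1-yl)methyl in place of 3,5-dimethyl-1H-pyrazol-1-yl on an aromatic carbon. Among the measured compounds shown here, no measured step bears on this change, and the only neighbours sit at the limit. For compound 3 the step that the limit leaves unreadable from compound 2 to compound 3 is expected to be none beyond the scatter. Compound 3 is estimated at 2000 nM, within 700 nM to 6000 nM.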

Compound 3, half-maximal inhibitory concentration: 270 nM
The estimate for compound 3 lay 7.4-fold (0.87 log units) above the measured number; the whole stated range lies above it.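

In this assay, the place para to a large group now gives a readable gain: (1H-pyrrol-1-yl)methyl in place of 3,5-dimethyl-1H-pyrazol-1-yl brings an at least 3.7-fold lower number from compound 2 to compound 3 (0.56 log units; beyond the scatter), and in place of 4H-1,2,4-triazol-4-yl it brings an at least 3.7-fold lower number from compound 1 to compound 3 (0.56 log units; beyond the scatter). Both steps give only a minimum size, and the step between compound 1 and compound 2 cannot be read, because the earlier compounds rest on a limit: the limit of > 1000 nM in this assay, at which 2 of the 3 values shown sit.

Compound 3 differs from compound 2 in both the ring and its attachment, and the compounds shown do not separate these two changes. Going by these compounds, how a 1H-pyrrol-1-yl group set directly on the ring or a benzyl group would compare remains open.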